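This account rests on a few compounds, and the source may have more. Where it says the series, first, only, none or still open, it means among the compounds named here.

Measured compounds:
- compound 1 `CC(C)(C)C(=O)C1=C(O)C(=O)N(c2ccc(-c3ccon3)cc2)C1c1ccccc1OCCO`: 2.9 mL/min/kg in an ADME assay on the whole organism (Rattus norvegicus) for pharmacokinetics; on this read-out lower numbers stand for slow clearance and higher numbers for fast clearance
- compound 2 `Cc1cc(-c2ccc(N3C(=O)C(O)=C(C(=O)C(C)(C)C)C3c3ccccc3OCCO)cc2)on1`: "not determined" (no result reported) in this assay
- compound 3 `Cc1noc(-c2ccc(N3C(=O)C(O)=C(C(=O)C(C)(C)C)C3c3ccccc3OCCO)cc2)n1`: "not determined" (no result reported) in this assay

Compound 3 therefore has no number of its own in this assay; the same holds for compound 2, so the only figure in the set belongs to compound 1, which in this assay gives 2.9 mL/min/kg. Where compound 3 stands relative to compound 1 cannot be told from what was reported.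

The step to compound 4 `CC(C)(C)C(=O)C1=C(O)C(=O)N(c2ccc(-c3ccsc3)cc2)C1c1ccccc1OCCO` is thiophen-3-yl in place of 3-methyl-1,2,4-oxadiazol-5-yl on an aromatic carbon. Since neither compound 3 nor any pair of measured compounds gives a step in this assay, no size or direction for this change can be read from the series; the expectation has to lean on compound 1 alone, whose value of 2.9 mL/min/kg is the single anchor for the shared core. On that basis a step is not expected to exceed the scatter, in either direction, with no evidence to favour faster or slower clearance. Compound 4 is expected to give about 4 mL/min/kg in this assay, with a plausible range from 1.5 mL/min/kg to 12 mL/min/kg for the estimate.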

Compound 4, clearance: 0.5 mL/min/kg
Compound 4: the middle estimate sits 8.0-fold (0.90 log units) above what was measured, and the stated range ends above it.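

Among the compounds shown here, with the shared core held fixed, thiophen-3-yl in place of 1,2-oxazol-3-yl gives a 5.8-fold lower number from compound 1 to compound 4 (0.76 log units; beyond the scatter) in this assay as the first step that can be read. The place on an aromatic carbon, para to a large group, therefore bears on this read-out, and exchanging one five-membered aromatic ring for another is enough to carry the number beyond the scatter, towards slower clearance. Nothing at hand speaks to the origin of this step, so it stands as an observation on a single pair.

Steps involving compound 2 or compound 3 cannot be read, so one pair is all that supports this change, and it remains open whether 3-methyl-1,2,4-oxadiazol-5-yl would sit closer to compound 1 or to compound 4. Also open, going by these compounds, is where a plain phenyl ring, a pyridine or a simple amine at this place would fall on the same read-out, and whether thiophen-3-yl would keep its effect on a different core.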